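Swapping the Ring on the Amide Nitrogen of a Weak Inhibitor

A few compounds are considered here, and "the series" means these few. Any claim that something is new, unique, unknown or untested is made for them only; others in the source may bear on it.

Compound 1, `COc1ncc(-c2ccc3c(c2)N(c2ccc(C)cc2)C(=O)CO3)cc1NS(=O)(=O)c1ccc(F)cc1`, is the starting point of this comparison. In a functional assay on HepG2 cells (Homo sapiens) for antiproliferative activity, read by MTT assay, with a stated time of 72 h (a lower number here means a stronger inhibitor, a higher number a weaker inhibitor), compound 1 gives 28300 nM, the lowest of the two plain numbers shown, though its nearest neighbour sits close: compound 2, `Cc1ccc(N2C(=O)COc3ccc(-c4cnc(Cl)c(NS(=O)(=O)c5ccc(F)cc5)c4)cc32)cc1`, gives 39600 nM in this assay. Among the compounds with values here, the only measured step, a 1.4-fold higher number from compound 1 to compound 2 (0.15 log units; within the scatter), puts chloro in place of methoxy on an aromatic carbon and stays within the scatter. Compound 3, `COc1cccc(N2C(=O)COc3ccc(-c4cccc(NS(=O)(=O)c5ccc(F)cc5)c4)cc32)c1`, reaches only a limit in this assay, namely > 40000 nM, so no number is known for it. This is the limit of > 40000 nM in this assay, at which 1 of the 3 values shown sits.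

Compound 4, `COc1cccc(N2C(=O)COc3ccc(-c4cnc(OC)c(NS(=O)(=O)c5ccc(F)cc5)c4)cc32)c1`, differs from compound 1 in one place: 3-methoxyphenyl in place of 4-methylphenyl on an amide-type nitrogen in a ring. Within the data shown here, no measured step covers this change. Compound 3 carries the same 3-methoxyphenyl but differs from compound 1 elsewhere as well, so its limit and the value of compound 1 show only that both lie at the weak end of this assay. Among the measured compounds shown here, the one step that is known, from compound 1 to compound 2, was small, and nothing here points to a large move.

Compound 4 is therefore expected to stay near compound 1, with an estimated step of a 1.2-fold higher number from compound 1 to compound 4 (0.09 log units; within the scatter). The estimated value for compound 4 in this assay is 35000 nM, within a range from 15000 nM to 60000 nM, and a limit instead of a number would not be surprising.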

Compound 4, half-maximal inhibitory concentration: > 40000 nM
Compound 4 ended at the assay's limit; the forecaster's own chance of this, stated with the estimate: 40%; middle value at least 1.1-fold (0.05 log units) away from the limit.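

Placing 3-methoxyphenyl where compound 1 has 4-methylphenyl, on the amide-type nitrogen in a ring, gives in this assay an at least 1.4-fold higher number from compound 1 to compound 4 (0.15 log units; that floor lies within the scatter). The reading for compound 4 is a limit and not a number, so this step is only a floor: the real gap could be small or much larger, and the floor alone does not clear the scatter. What is new is that this position has now been changed on its own, with the rest of compound 1 held fixed, and the swap brought no gain in strength, while a second compound carrying 3-methoxyphenyl joins compound 3 at the limit: the limit of > 40000 nM in this assay, at which 2 of the 4 values shown sit.

From the compounds shown here alone, both groups tried at this position are single six-membered aromatic rings of carbon only, so it remains open whether anything of a different kind placed on this nitrogen, such as a short alkyl chain, a saturated ring or a chain ending in an amine or a carboxylic acid, would move the value in either direction. Also open, going by these compounds, is how far compound 4 really lies from compound 1, which only a number in place of the limit could settle.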